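The compounds below may be only part of what the source reports. "The series", "measured", "known", "first", "only" and "open" are said of these compounds alone.

Going by the values given here, compound 2 `Fc1ccc(-c2nc(-c3ccc4nc[nH]c4c3)no2)cc1` gives the lowest of the two numbers so far in a physicochemical assay for lipophilicity, using potentiometric titration, at pH 7.4 (a higher number here means a more lipophilic compound, a lower number a more polar compound), namely 3.37; compound 1 `c1ccc(-c2nc(-c3ccc4nc[nH]c4c3)no2)cc1` gives 3.66, and the step of a number 0.29 log units lower from compound 1 to compound 2 (within the scatter) is within the scatter. Compound 3 `OCCCCCc1ccc(-c2nc(-c3ccc4nc[nH]c4c3)no2)cc1` differs from compound 2 by 5-hydroxypentyl in place of fluoro on an aromatic carbon. Among the compounds with values here, only the step from compound 1 to compound 2 bears on it, and it tells little beyond the fluoro-to-hydrogen part; no measured step covers the 5-hydroxypentyl group. Compound 3 is expected to rise by a number 1.23 log units higher from compound 2 to compound 3 (beyond the scatter) in this assay, to an estimated 4.6, between 3.9 and 5.3.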

Compound 3, distribution coefficient: 3.51
The estimate for compound 3 lay 1.09 log units above the measured number; the whole stated range lies above it.
By their numbers in this assay, from the lowest: compounds 2, 3 and 1 (each within the scatter of the next).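

At this position, on an aromatic carbon para to a large group, this assay does not separate the three compounds: 5-hydroxypentyl in place of fluoro gives a number 0.14 log units higher from compound 2 to compound 3 (within the scatter) and 5-hydroxypentyl in place of hydrogen gives a number 0.15 log units lower from compound 1 to compound 3 (within the scatter). The position thus takes a much larger group, one with a hydrogen-bond donor and acceptor, without a step beyond the scatter. No measurement at hand accounts for this result.

Open, from the compounds shown here alone, is how a plain pentyl chain without the hydroxyl would read here, and whether an amine or a carboxylic acid at this position would give a step beyond the scatter.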